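Trimming a chain tail on a cytotoxicity read-out

The source may hold more compounds than are shown below. What is called first, only, known or untested is meant among the compounds shown, and "the series" means these compounds.

Compound 1 `CCCCc1ccc(-c2cc3cn([C@H]4C[C@H](O)[C@@H](CO)O4)c(=O)nc3s2)cc1` and compound 2 `CCCCCCCc1ccc(-c2cc3cn([C@H]4C[C@H](O)[C@@H](CO)O4)c(=O)nc3s2)cc1` share one core and differ only in the length of a saturated chain. In a functional assay on HeLa cells (Homo sapiens) for cytotoxicity, read by microscopy (on this read-out lower numbers stand for higher toxicity in this test and higher numbers for lower toxicity in this test), compound 1 gives 50000 nM, and compound 2 gives 50000 nM. The step of no change at the digits printed from compound 1 to compound 2 (within the scatter) shows that lengthening the chain left the read-out unchanged within the scatter, so compound 2 stands level with compound 1 on this assay. Compound 3 `CCCCCc1ccc(-c2cc3cn([C@H]4C[C@H](O)[C@@H](CO)O4)c(=O)nc3s2)cc1` is reached from compound 2 by the change (hydrogen in place of ethyl on a saturated chain carbon, five bonds along the chain from an aromatic carbon), which shortens the chain again. Among the measured compounds shown here, only one measured step bears on this change, and it was flat, so the step of no change at the digits printed from compound 2 to compound 3 (within the scatter) is expected to be no change beyond the scatter in this assay. Compound 3 is therefore expected to give 50000 nM in this assay, with a range from 25000 nM to 100000 nM.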

Compound 3, minimum cytotoxic concentration: 50000 nM
Compound 3: the middle estimate sits on the measured number at the digits printed; the range from low to high includes it.
By their numbers in this assay, from the lowest: compounds 1, 2 and 3 (each within the scatter of the next).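

Removing ethyl at this saturated chain carbon gives no change at the digits printed from compound 2 to compound 3 (within the scatter) in this assay, and placing methyl on the chain carbon four bonds along from an aromatic carbon gives no change at the digits printed from compound 1 to compound 3 (within the scatter) on the same read-out. The earlier step showed only that one lengthening left the read-out flat, whereas this result shows that a shortening is flat too and that a chain of intermediate length sits level with both neighbours, so all three compounds lie within the scatter of one another. No measurement at hand offers a reason for this flat behaviour.

Going by these compounds, whether a longer chain, or an amine or a carboxylic acid in place of the chain, would move this read-out stays open. These three compounds also cannot show how chain length acts in any other test.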